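The source may hold more compounds than are shown below. What is called first, only, known or untested is meant among the compounds shown, and "the series" means these compounds.

Compound 3 `COc1ccc(-n2ccc(=O)c(C(=O)Nc3ccc(Oc4ccnc5[nH]ccc45)c(F)c3)n2)cc1` gives > 60000 nM in a functional assay on A549 cells (Homo sapiens) for cytotoxicity, read by MTT assay, with a stated time of 72 h (on this read-out lower numbers stand for stronger inhibition and higher numbers for weaker inhibition), which is a limit of the assay and not a number. Compound 2 `O=C(Nc1ccc(Oc2ccnc3[nH]ccc23)c(F)c1)c1nn(-c2ccc(Cl)cc2)ccc1=O` likewise gives only a limit, > 60000 nM. Among the measured compounds shown here, compound 1 `COc1ccc(-n2ccc(=O)c(C(=O)Nc3ccc(Oc4ccnc5[nH]ccc45)cc3)n2)cc1` gives 53100 nM, the one true number so far. The series thus rests largely on (the limit of > 60000 nM in this assay, at which 2 of the 3 values shown sit).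

Compound 4 `COc1ccc(-n2ccc(=O)c(C(=O)Nc3ccc(Oc4ccnc5c4ccn5C)c(F)c3)n2)cc1` differs from compound 3 by methyl in place of hydrogen on an aromatic nitrogen. For the measured compounds named here, no measured step touches that nitrogen. Fluoro in place of hydrogen gives an at least 1.1-fold higher number from compound 1 to compound 3 (0.05 log units; that floor lies within the scatter), and methoxy in place of chloro gives a step that the two limits leave unreadable from compound 2 to compound 3. Neither supports a size or direction, so no step beyond the scatter is expected in this assay, with an estimated a number no higher from compound 3 to compound 4 (the limit leaves the size open). For compound 4 the expected value is 60000 nM, with an estimated range of 25000 nM to 120000 nM.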

Compound 4, half-maximal inhibitory concentration: > 60000 nM
Compound 4 ended at the assay's limit; the forecaster's own chance of this, stated with the estimate: 70%; the middle value lies on the limit itself.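

No step can be read from compound 3 to compound 4, since both values in this assay are limits and not numbers. Whether methyl in place of hydrogen on an aromatic nitrogen changes the value at all stays open, and the series rests largely on one limit: the limit of > 60000 nM in this assay, at which 3 of the 4 values shown sit.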